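Compound 3 to compound 4: one methoxy fewer

A few compounds are considered here, and "the series" means these few. Any claim that something is new, unique, unknown or untested is made for them only; others in the source may bear on it.

In a functional assay on 1-87 cells (Homo sapiens) for cytotoxicity (a higher number here means a weaker inhibitor, a lower number a stronger inhibitor), compound 1 (`COc1ccc(/C=C\c2cc(OC)c(OC)c(OC)c2)cc1B(O)O`) gives 13 nM and compound 2 (`COc1cc(/C=C\c2ccc(B(O)O)cc2)cc(OC)c1OC`) gives 3200 nM in the same series. For the measured compounds named here, compound 3 (`COc1cc(/C=C\c2cccc(B(O)O)c2)cc(OC)c1OC`) gives 2100 nM and so lies within the scatter of compound 2 and far from compound 1, with only those three numbers available so far.

Compound 4 (`COc1cc(/C=C\c2cccc(B(O)O)c2)cc(OC)c1`) has hydrogen in place of methoxy on an aromatic carbon, ortho to two methoxy groups and para to a large group, with hydrogen in place of methoxy on an aromatic carbon as the counted change from compound 3.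

One measured step is of the same kind, namely a 160-fold higher number from compound 1 to compound 3 (2.21 log units; beyond the scatter) in this assay and beyond the scatter. That methoxy left the other six-membered aromatic ring, however, so this step bears on the direction only loosely and says little about size. Going by the values given here, no measured step touches the ring changed here.

A moderate move to a higher number is therefore expected, smaller than that large step. The expected change is a 2.4-fold higher number from compound 3 to compound 4 (0.38 log units; beyond the scatter) on this reasoning, with wide uncertainty.

For compound 4 the estimated value is 5000 nM with 1500 nM to 20000 nM as the expected range.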

Compound 4, half-maximal inhibitory concentration: 2000 nM
Compound 4: middle estimate off by 2.5-fold (0.40 log units), on the high side; low and high end bracket the measured number.
By their numbers in this assay, from the lowest: compound 1; then compounds 4, 3 and 2 (each within the scatter of the next).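

Working notes on the position just changed: in this assay, hydrogen in place of methoxy on this aromatic carbon, ortho to two methoxy groups and para to a large group, gives a 1.1-fold lower number from compound 3 to compound 4 (0.02 log units; within the scatter) and so leaves the read-out within the scatter. The same counted change on the other six-membered aromatic ring gives a 160-fold higher number from compound 1 to compound 3 (2.21 log units; beyond the scatter) and lies beyond the scatter, so in these two steps the outcome depends on which ring carries the change, and compound 4 shows that the third methoxy of compound 3 is not needed to hold the number at this level. No supporting data are at hand to account for this flat step.

Still open, going by these compounds, is whether the same change on the core of compound 1 (13 nM) would also stay within the scatter, as compound 3 and compound 4 both lack the methoxy that sits on the other ring of compound 1. Also open, on these data alone, is whether anything other than methoxy or hydrogen at this place, such as an amine, a carboxylic acid or a longer alkoxy chain like butoxy, would move the number in this assay at all.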